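The source may hold more compounds than are shown below. What is called first, only, known or untested is meant among the compounds shown, and "the series" means these compounds.

Of the compounds shown here, three that share one core have been tested in a functional assay on MOLT-4 cells (Homo sapiens) for inhibition, read by MTT assay, with a stated time of 4 days; a lower number here means a stronger inhibitor, a higher number a weaker inhibitor. Compound 1 `COc1cc(NC(C)CCCNC(=O)NCCNC(c2ccccc2)(c2ccccc2)c2ccccc2)c2ncccc2c1` gives 210000 nM in this assay. Compound 3 `COc1cc(NC(C)CCCNC(=O)NNC(=O)N(C)C(c2ccccc2)c2ccccc2)c2ncccc2c1` gives 19000 nM. Compound 2 `COc1cc(NC(C)CCCNC(=O)NNC(=O)N(CCO)CCO)c2ncccc2c1` reaches only the limit of the assay, > 250000 nM, so no number is known for it. This places compound 2 at the limit of > 250000 nM in this assay, at which 1 of the 3 values shown sits. The next compound, compound 4 `COc1cc(NC(C)CCCNC(=O)NNC(=O)NC(CO)(CO)CO)c2ncccc2c1`, differs from compound 2 at one place: (2-hydroxy-1,1-bis(hydroxymethyl)ethyl)amino in place of bis(2-hydroxyethyl)amino on a carbonyl carbon The group that leaves and the group that enters are both uncharged chains without a ring, and the change is a small one on the outer end of the molecule. Within the data shown here, no measured pair of compounds shows what such a swap does, and compound 2 itself stands at the limit, so the expected step of a number no higher from compound 2 to compound 4 (the limit leaves the size open) is none beyond the scatter. Compound 4 is therefore expected to give about 250000 nM in this assay, between 100000 nM and 600000 nM, and most probably to be reported again only as a limit.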

Compound 4, half-maximal inhibitory concentration: > 250000 nM
Compound 4 ended at the assay's limit (the forecaster's own chance of this, stated with the estimate: 70%); the middle value sits exactly at the limit.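

Among these compounds, no step from compound 2 to compound 4 can be read in this assay, since each is reported only as a limit, not a number: the limit of > 250000 nM in this assay, at which 2 of the 4 values shown sit. The compounds shown leave open whether (2-hydroxy-1,1-bis(hydroxymethyl)ethyl)amino in place of bis(2-hydroxyethyl)amino changes inhibition at all, and in which direction.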